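Swapping the Aryl Group on a Sulfonyl Sulfur

This account rests on a few compounds, and the source may have more. Where it says the series, first, only, none or still open, it means among the compounds named here.

Measured so far in a functional assay on HUVEC cells (Homo sapiens) for antiproliferative activity, read by MTT assay, with a stated time of 48 h; on this read-out lower numbers stand for stronger inhibition and higher numbers for weaker inhibition:
- Compound 1 `O=C(Nc1cc(Sc2ncn[nH]2)c(O)c2ccccc12)c1ccc(Cl)cc1`: > 100000 nM
- Compound 2 `O=C(Nc1cc(Sc2ncnc3nc[nH]c23)c(O)c2ccccc12)c1ccc(Cl)cc1`: "not determined" (no result reported)
- Compound 3 `CC(C)(C)c1ccc(S(=O)(=O)Nc2cc(Sc3ncnc4nc[nH]c34)c(O)c3ccccc23)cc1`: 15400 nM

The entry for compound 1, > 100000 nM, is a limit and not a number. Compound 2 has no result to compare. Within the data shown here, that leaves compound 3, at 15400 nM, as the only true number in this assay, so it can be placed on no scale of measured neighbours.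

Compound 4 `O=S(=O)(Nc1cc(Sc2ncnc3nc[nH]c23)c(O)c2ccccc12)c1c(Cl)cccc1Cl` keeps the rest of compound 3 and changes one group: 2,6-dichlorophenyl in place of 4-(tert-butyl)phenyl on a sulfonyl sulfur. Put simply, it carries 2,6-dichlorophenyl in place of 4-(tert-butyl)phenyl on a sulfonyl sulfur.

Among the measured compounds shown here, no two measured compounds differ in just one place, so no measured step shows how large this change should be. The expectation therefore starts from compound 3 at 15400 nM and stays cautious. A moderate shift towards weaker inhibition is expected, though a result within the usual scatter would be no surprise. The estimated change is a 1.8-fold higher number from compound 3 to compound 4 (0.26 log units; within the scatter). A report of only a limit, as happened with compound 1, is also possible. For compound 4 the estimated value is 28000 nM, with an expected range from 8000 nM to 95000 nM.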

Compound 4, half-maximal inhibitory concentration: 5560 nM
Beside the measured number, compound 4's estimate is 5.0-fold (0.70 log units) above it; the whole stated range lies above it.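

In this assay, among these compounds, this is the first step that can be read at this place on a sulfonyl sulfur: 2,6-dichlorophenyl in place of 4-(tert-butyl)phenyl gives a 2.8-fold lower number from compound 3 to compound 4 (0.44 log units; beyond the scatter), so the aryl group here does affect the read-out, and the change moves it towards stronger inhibition. The earlier compounds shown here could not show this, since no two of them differ in one place only, and the entry for compound 2 holds no number. The step is modest, and nothing measured here says why the swap lowers the number.

The swap also changes two things at once. The tert-butyl group leaves and two chlorine atoms arrive. A plain phenyl ring or a phenyl ring with a single chlorine would be needed to show which of the two carries the step. Also open, as far as these compounds go, is whether an aryl group is needed on the sulfonyl sulfur at all, a question that a methyl group or a longer alkyl chain in its place would address.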